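Indole series: N-methylation of compound 3 to compound 4

This account rests on a few compounds, and the source may have more. Where it says the series, first, only, none or still open, it means among the compounds named here.

Measured so far:
compound 1 `CN(C(=O)c1cc2ccccc2n1C)c1ccccc1` 15 nM
compound 2 `O=C(NCCCCc1ccccc1)c1cc2ccccc2[nH]1` 2200 nM
compound 3 `c1ccc(NCc2cc3ccccc3[nH]2)cc1` 10000 nM

In an assay for inhibition of Amine oxidase [flavin-containing] A (Bos taurus), read by fluorescence (a higher number here means a weaker inhibitor, a lower number a stronger inhibitor), compound 3 gives the highest number of the three, beyond the scatter from compound 2 and far beyond it from compound 1. Compound 4 `Cn1c(CNc2ccccc2)cc2ccccc21` differs from compound 3 by methyl in place of hydrogen on an aromatic nitrogen. Going by the values given here, no measured pair isolates this change; compound 1 also carries a methyl on an aromatic nitrogen but differs in several other places, so its value in this assay cannot be credited to that methyl. A small gain in this assay, within or just beyond the scatter, is expected for compound 4, as a 2.0-fold lower number from compound 3 to compound 4 (0.30 log units; within the scatter). Compound 4 is estimated at 5000 nM, expected between 1000 nM and 20000 nM.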

Compound 4, inhibition constant: 10 nM
Compound 4: middle estimate off by 500-fold (2.70 log units), on the high side, outside the stated range (below it).
By their numbers in this assay, from the lowest: compounds 4 and 1 (each within the scatter of the next); then compound 2; then compound 3.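

In this assay, methyl in place of hydrogen on an aromatic nitrogen gives a 1000-fold lower number from compound 3 to compound 4 (3.00 log units; beyond the scatter). Going by these compounds alone, this is the first step that isolates this position, and it shows that a change of one carbon at this nitrogen is enough for a large shift in the number. Nothing available here accounts for the size of this step.

Going by these compounds, whether ethyl or a longer chain on this nitrogen keeps the gain remains open. So does whether the same methyl would give a comparable step on compound 2, whose aromatic nitrogen still bears hydrogen.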